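The compounds below may be only part of what the source reports. "The series", "measured", "known", "first", "only" and "open" are said of these compounds alone.

Working notes on the ester series. The shared core carries a varying ester on an oxygen next to a carbonyl group: compound 1 `C[C@@H](O)[C@H]1C(=O)N2C(C(=O)OCOC(=O)C(C)(C)C)=C(S[C@@H]3CN[C@H](C(=O)Nc4cccc(C(=O)O)c4)C3)[C@H](C)[C@H]12`, compound 2 `C[C@@H](O)[C@H]1C(=O)N2C(C(=O)OCOC(=O)OC(C)(C)C)=C(S[C@@H]3CN[C@H](C(=O)Nc4cccc(C(=O)O)c4)C3)[C@H](C)[C@H]12` and compound 3 `CC(C)OC(=O)C1=C(S[C@@H]2CN[C@H](C(=O)Nc3cccc(C(=O)O)c3)C2)[C@H](C)[C@@H]2[C@@H]([C@@H](C)O)C(=O)N12`. In an ADME assay for metabolic stability, read by LC-MS, with a stated time of 3 h, at pH 6.5, tested at 50 uM (a lower number here means that less of the compound is left, a higher number that more of the compound is left), compound 1 gives > 95%, which is a limit of the assay and not a number. Compound 2 likewise gives > 95%, again a limit. Compound 3 gives > 95%, also a limit. The measured steps are thus unreadable in size: a step that the two limits leave unreadable from compound 1 to compound 2; a step that the two limits leave unreadable from compound 1 to compound 3; a step that the two limits leave unreadable from compound 2 to compound 3. What the three values show is the limit of > 95% in this assay, at which 3 of the 3 values shown sit.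

Compound 4 `CCOC(=O)OCOC(=O)C1=C(S[C@@H]2CN[C@H](C(=O)Nc3cccc(C(=O)O)c3)C2)[C@H](C)[C@@H]2[C@@H]([C@@H](C)O)C(=O)N12` is the next ester variant. The change from compound 3 is ((ethoxycarbonyl)oxy)methyl in place of isopropyl on an oxygen next to a carbonyl group. Within the data shown here, no measured step bears on this change with a readable size; three esters of quite different build all sit at the limit, and no ester variant falls short of it. Compound 4 is therefore expected to sit at the same limit, with an estimate of 97% and a range from 85% to 100%. The expected step is a step that the limit leaves unreadable from compound 3 to compound 4, nothing beyond the scatter.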

Compound 4, percent of the compound remaining: > 95%
Compound 4 gave a limit, no number (the forecaster's own chance of this, stated with the estimate: 80%); the middle value does not contradict the limit.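

In this assay compound 4 gives > 95%, a limit and not a number, so no new step can be read between compound 4 and compound 1, compound 2 or compound 3. Compounds 1 to 4 leave open whether these esters differ at all, because all stand at one limit: the limit of > 95% in this assay, at which 4 of the 4 values shown sit.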